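A few compounds are considered here, and "the series" means these few. Any claim that something is new, unique, unknown or untested is made for them only; others in the source may bear on it.

Measured compounds:
- compound 1, `CNC(=O)c1cc(Oc2ccc(NC(=O)c3cc4cccnc4n(-c4ccccc4F)c3=O)cc2)ccn1`: in a functional assay on A549 cells (Homo sapiens) for antiproliferative activity, read by MTT assay, with a stated time of 72 h (on this read-out lower numbers stand for stronger inhibition and higher numbers for weaker inhibition), compound 1 gives 610 nM
- compound 2, `CNC(=O)c1cc(Oc2ccc(NC(=O)c3cc4cccnc4n(-c4ccc(F)cc4)c3=O)cc2)ccn1`: in this assay compound 2 gives 110 nM
- compound 3, `CCCNC(=O)c1cc(Oc2ccc(NC(=O)c3cc4cccnc4n(-c4ccccc4F)c3=O)cc2)ccn1`: in this assay compound 3 gives 150 nM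

Compound 1 serves as the common starting point for two single changes. The first is 4-fluorophenyl in place of 2-fluorophenyl on an aromatic nitrogen; it produced a 5.5-fold lower number from compound 1 to compound 2 (0.74 log units; beyond the scatter). The second is ethyl in place of hydrogen on a saturated chain carbon bound to an amide-type nitrogen; it produced a 4.1-fold lower number from compound 1 to compound 3 (0.61 log units; beyond the scatter). Compound 2 and compound 3 give numbers that lie within the scatter of each other, so nothing separates them.

Compound 4, `CCCNC(=O)c1cc(Oc2ccc(NC(=O)c3cc4cccnc4n(-c4ccc(F)cc4)c3=O)cc2)ccn1`, has not yet been measured in this assay. It is related to compound 3 by 4-fluorophenyl in place of 2-fluorophenyl on an aromatic nitrogen. This is the same change already seen between compound 1 and compound 2, and it sits in the same surroundings in both pairs: the cores of compound 1 and compound 3 differ only by ethyl in place of hydrogen on a saturated chain carbon bound to an amide-type nitrogen. Because a 5.5-fold lower number from compound 1 to compound 2 (0.74 log units; beyond the scatter) was found once, a step of similar direction is expected from compound 3 to compound 4, estimated as a 4.3-fold lower number from compound 3 to compound 4 (0.63 log units; beyond the scatter). The expectation is somewhat tempered: the two changes have been observed only once each, and whether they add together fully in a single compound is not known from the three measured compounds. On that basis compound 4 is estimated in this assay at 35 nM, with a range from 12 nM to 100 nM.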

Compound 4, half-maximal inhibitory concentration: 62 nM
Estimate against measurement, compound 4: 1.8-fold (0.25 log units) below; the measured number falls inside the stated range.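

In this assay, 4-fluorophenyl in place of 2-fluorophenyl on an aromatic nitrogen kept its direction on the second core, giving a 2.4-fold lower number from compound 3 to compound 4 (0.38 log units; beyond the scatter), and its size there cannot be told apart from that of the earlier step: the same change on two cores in this assay, a 5.5-fold lower number (0.74 log units; beyond the scatter) from compound 1 to compound 2 and a 2.4-fold lower number (0.38 log units; beyond the scatter) from compound 3 to compound 4, 2.3-fold (0.36 log units) apart, within the scatter of two such steps

The other change, ethyl in place of hydrogen on a saturated chain carbon bound to an amide-type nitrogen, gave a 1.8-fold lower number from compound 2 to compound 4 (0.25 log units; within the scatter) on the core carrying 4-fluorophenyl, so on that core it cannot be separated from no change at all, yet it too cannot be told apart from its earlier step: the same change on two cores in this assay, a 4.1-fold lower number (0.61 log units; beyond the scatter) from compound 1 to compound 3 and a 1.8-fold lower number (0.25 log units; within the scatter) from compound 2 to compound 4, 2.3-fold (0.36 log units) apart, within the scatter of two such steps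

Among these compounds, each change has been seen on only two cores, so these four compounds are consistent with carrying both from one core to another, but they neither establish that the steps are of equal size nor show that the second steps are truly smaller than the first.

From the compounds shown here alone, whether the same picture would hold with an unsubstituted phenyl or a methoxyphenyl on the aromatic nitrogen remains open. So does the outcome for a longer chain, a branched chain or a cyclopropyl group on the amide nitrogen, on either core.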